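The source may hold more compounds than are shown below. What is called first, only, known or untested is meant among the compounds shown, and "the series" means these compounds.

In a functional assay on HCT-116 cells (Homo sapiens) for cytotoxicity, read by crystal violet staining, with a stated time of 7 days (a lower number here means a stronger inhibitor, a higher number a weaker inhibitor), compound 3 (`COc1ccc2c(c1)C=C(C(=O)/C=C/c1cc(OC)c(OC)cc1OC)CO2`) gives 2500 nM, within the scatter of compound 2 (`COc1ccc2c(c1)C=C(C(=O)/C=C/c1ccccc1OC)CO2`) at 1620 nM. Compound 1 (`COc1ccc(/C=C/C(=O)C2=Cc3cc(OC)ccc3OC2)cc1`) gives 590 nM, a lower number beyond the scatter of both. Compound 4 (`COc1ccc2c(c1)C=C(C(=O)/C=C/c1ccc(OC)cc1OC)CO2`) differs from compound 3 by hydrogen in place of methoxy on an aromatic carbon, para to a methoxy group. Among the compounds with values here, no measured step removes a methoxy group directly. The nearest evidence is a 2.7-fold higher number from compound 1 to compound 2 (0.44 log units; beyond the scatter), with 2-methoxyphenyl in place of 4-methoxyphenyl. Compound 3, with its extra methoxy groups, stays within the scatter of compound 2 at 1620 nM, so no step beyond the scatter is expected. The expected move is a 1.6-fold lower number from compound 3 to compound 4 (0.19 log units; within the scatter). For compound 4, the estimate is 1600 nM, with an expected range of 700 nM to 3500 nM.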

Compound 4, half-maximal inhibitory concentration: 3970 nM
The estimate for compound 4 lay 2.5-fold (0.39 log units) below the measured number; the whole stated range lies below it.
By their numbers in this assay, from the lowest: compound 1; then compounds 2, 3 and 4 (each within the scatter of the next, the first and the last beyond it).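

In this assay, hydrogen in place of methoxy at this position, ortho to a methoxy group and para to a methoxy group, leaves the number within the scatter (a 1.6-fold higher number from compound 3 to compound 4 (0.20 log units; within the scatter)), so the methoxy group here has no effect that can be read. Methoxy in place of hydrogen elsewhere on this ring gives larger steps, both beyond the scatter (a 2.5-fold higher number from compound 2 to compound 4 (0.39 log units; beyond the scatter); a 6.7-fold higher number from compound 1 to compound 4 (0.83 log units; beyond the scatter)). No measurement bears on the reason for these steps.

On these data alone, whether an amine or a hydroxyl at this position would also stay within the scatter remains open.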